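The source may report more compounds than this note shows. Statements on the series, on what has been measured and on what is new or still open speak of the compounds shown alone.

Of the compounds shown here, three that share one core have been measured in a functional assay, with a stated time of 20 min, tested at 10 uM; on this read-out lower numbers stand for a weaker effect and higher numbers for a stronger effect at the one concentration tested. Compound 3, `COc1cc(/C=C/C(=O)C2=C(/C=C/c3ccc(O)c(OC)c3)NC(=O)NC2c2ccccc2O)ccc1O`, gives 71%, the highest of the three numbers. Compound 1, `COc1cc(/C=C/C(=O)C2=C(/C=C/c3ccc(O)c(OC)c3)NC(=O)NC2c2ccccc2)ccc1O`, gives 20%, and compound 2, `COc1cc(/C=C/C(=O)C2=C(/C=C/c3ccc(O)c(OC)c3)NC(=O)NC2c2ccc(C)cc2)ccc1O`, gives 23.9%. The step of a number 51 percentage points higher from compound 1 to compound 3 (beyond the scatter) was large and beyond the scatter, as was a number 47.1 percentage points higher from compound 2 to compound 3 (beyond the scatter); by contrast a number 3.9 percentage points higher from compound 1 to compound 2 (within the scatter) stayed within the scatter.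

Compound 4, `COc1cc(/C=C/C(=O)C2=C(/C=C/c3ccc(O)c(OC)c3)NC(=O)NC2c2ccc(O)cc2)ccc1O`, is the next compound to be measured, and its difference from compound 3 is 4-hydroxyphenyl in place of 2-hydroxyphenyl on a saturated ring carbon. The two steps that lead to compound 3 both show that a 2-hydroxyphenyl on the saturated ring carbon went with a large rise in this assay, whereas the methyl on an aromatic carbon in compound 2 left the number within the scatter of compound 1. Compound 4 keeps a hydroxy on that phenyl, but as 4-hydroxyphenyl, and the comparisons at hand do not show whether the large effect seen with 2-hydroxyphenyl carries over. For compound 4 the expected step is therefore a number 31 percentage points lower from compound 3 to compound 4 (beyond the scatter), a retreat toward the other two numbers with wide uncertainty. Compound 4 is thus estimated at 40%, within a range from 15% to 72%.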

Compound 4, a percentage reported as activity, at one concentration (the size of the read-out at that concentration, not a potency): 72%
Compound 4: middle estimate off by 32 percentage points, on the low side; the measured number falls inside the stated range.
By their numbers in this assay, from the lowest: compounds 1 and 2 (each within the scatter of the next); then compounds 3 and 4 (each within the scatter of the next).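

In this assay, 4-hydroxyphenyl in place of 2-hydroxyphenyl on the saturated ring carbon gave a number 1 percentage points higher from compound 3 to compound 4 (within the scatter), so among these compounds the large rise is not confined to the 2-hydroxyphenyl group. Compound 4 also stands well clear of the two compounds without a hydroxy on that phenyl, with a number 52 percentage points higher from compound 1 to compound 4 (beyond the scatter) and a number 48.1 percentage points higher from compound 2 to compound 4 (beyond the scatter), whereas a methyl in the same place as that hydroxy gave only a number 3.9 percentage points higher from compound 1 to compound 2 (within the scatter). Across these four compounds, then, both hydroxyphenyl compounds read high and the phenyl and 4-methylphenyl compounds read low, with no compound going against that split, although no measured information here explains it.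

Whether the high reading requires a free hydroxy remains open, since the compounds shown do not include a methoxy, an amine or a carboxylic acid on that phenyl. With a single tested concentration, they also leave open whether compound 3 and compound 4 would still read alike at other concentrations.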